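Methyl on the indole-type core: a step read only one way

A few compounds are considered here, and "the series" means these few. Any claim that something is new, unique, unknown or untested is made for them only; others in the source may bear on it.

Notes on the series. Compound 1 `COc1ccc(/C(Cl)=C/C=C(\C#N)C(=O)c2c(C)[nH]c3ccccc23)cc1`, compound 2 `N#C/C(=C\C=C(/Cl)c1ccc(Br)cc1)C(=O)c1c[nH]c2ccccc12` and compound 3 `COc1ccc(/C(Cl)=C/C=C(\C#N)C(=O)c2c[nH]c3ccccc23)cc1` share one core and were all run in a functional assay on MCF7 cells (Homo sapiens) for cytotoxicity, read by sulforhodamine B assay, with a stated time of 48 h; on this read-out higher numbers stand for weaker inhibition of growth and lower numbers for stronger inhibition of growth. Compound 1 stops at a limit of the assay, giving > 100000 nM. Compound 3 likewise stops at a limit, giving > 100000 nM. Among the compounds with values here, compound 2 is the one compound that returns a number, giving 81500 nM; against it, two of the three values sit at the limit of > 100000 nM in this assay, at which 2 of the 3 values shown sit.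

Compound 4 `Cc1[nH]c2ccccc2c1C(=O)/C(C#N)=C/C=C(\Cl)c1ccc(Br)cc1` is not yet measured. It differs from compound 2 by methyl in place of hydrogen on an aromatic carbon. Within the data shown here, two measured steps bear on this change. The same methyl, taken off in the other direction, gives a step that the two limits leave unreadable from compound 1 to compound 3, so its size cannot be read. The bromo-to-methoxy exchange gives an at least 1.2-fold higher number from compound 2 to compound 3 (0.08 log units; that floor lies within the scatter), which only sets a floor. For compound 4 no movement beyond the scatter is therefore expected, and the expected step is a 1.1-fold higher number from compound 2 to compound 4 (0.04 log units; within the scatter). The estimate for compound 4 is 90000 nM, within 40000 nM to 200000 nM.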

Compound 4, concentration for total growth inhibition: 73800 nM
The estimate for compound 4 lay 1.2-fold (0.09 log units) above the measured number; the range from low to high includes it.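

In this assay the methyl on the aromatic carbon next to the ring nitrogen can now be read on the bromo compounds: a 1.1-fold lower number from compound 2 to compound 4 (0.04 log units; within the scatter), a step that stays within the scatter. With that methyl in place, bromo in place of methoxy gives an at least 1.3-fold lower number from compound 1 to compound 4 (0.13 log units; that floor lies within the scatter), which is a floor and not a size, and it pairs with the same change on the core without the methyl: the same change on two cores in this assay, an at least 1.2-fold higher number (0.08 log units; that floor lies within the scatter) from compound 2 to compound 3 and an at least 1.3-fold higher number (0.13 log units; that floor lies within the scatter) from compound 4 to compound 1; the limit leaves it open whether they differ The step from compound 1 to compound 3 still cannot be read, and the methoxy compounds stay at the limit: the limit of > 100000 nM in this assay, at which 2 of the 4 values shown sit.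

Within the data shown here, whether the methyl step on the methoxy compounds matches the one on the bromo compounds stays open. Also open, from the compounds shown here alone, is whether a longer chain or an amine in place of that methyl would move the number beyond the scatter.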